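A few compounds are considered here, and "the series" means these few. Any claim that something is new, unique, unknown or untested is made for them only; others in the source may bear on it.

Working notes on the series: in a functional assay on A-375 cells (Homo sapiens) for inhibition, read by CCK-8 assay, with a stated time of 72 h, tested at 2 uM (on this read-out higher numbers stand for more inhibition of growth at the one concentration tested and lower numbers for less inhibition of growth), compound 1 `Nc1ccccc1NC(=O)/C=C/c1ccc(CSc2cccc(F)c2)cc1` gives 6.75% and compound 2 `Nc1ccccc1NC(=O)/C=C/c1ccc(CSc2ccc(F)cc2)cc1` gives 28.8%, the higher of the two numbers so far. Next is compound 3 `Nc1ccccc1NC(=O)/C=C/c1ccc(CSCCc2ccccc2)cc1`, with phenethyl in place of 4-fluorophenyl on a sulfur. Among the measured compounds shown here, the only measured step at this sulfur, a number 22.1 percentage points higher from compound 1 to compound 2 (beyond the scatter), swaps one fluorophenyl group for another, and no measured compound carries phenethyl. That step shows that this assay responds to changes here, so a modest fall is expected, with the estimated step being a number 13.8 percentage points lower from compound 2 to compound 3 (beyond the scatter). For compound 3 the expected value is 15%, with an estimated range of 3% to 35%.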

Compound 3, percent growth inhibition at one concentration: 41.9%
Compound 3: the middle estimate sits 26.9 percentage points below what was measured; measured number outside the range, above it.
By their numbers in this assay, from the lowest: compound 1; then compound 2; then compound 3.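

In this assay, phenethyl on the sulfur gives a number 13.1 percentage points higher from compound 2 to compound 3 (beyond the scatter), and measured against the other fluorophenyl group it gives a number 35.2 percentage points higher from compound 1 to compound 3 (beyond the scatter). Compound 3 therefore holds the highest number of the three, and a fluorophenyl group on this sulfur is not needed for growth inhibition at the one concentration tested. Nothing available accounts for this rise.

Phenethyl differs from 4-fluorophenyl in both the chain and the fluorine, and these two changes remain unseparated. A 4-fluorophenethyl group, a benzyl group or a longer chain ending in phenyl would pull them apart.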